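The source may report more compounds than this note shows. Statements on the series, on what has been measured and on what is new or still open speak of the compounds shown alone.

compound 1 `Cc1ccccc1NC(=O)CN1CCN(c2nnc(Cc3ccccc3)c3ccccc23)CC1` with 17300 nM
compound 2 `O=C(CN1CCN(c2nnc(Cc3ccncc3)c3ccccc23)CC1)Nc1ccc(F)c(Cl)c1` with 4 nM

In a functional assay on MDA-MB-231 cells (Homo sapiens) for cytotoxicity, read by MTT assay, with a stated time of 72 h (on this read-out higher numbers stand for weaker inhibition and lower numbers for stronger inhibition), compound 2 at 4 nM is the lower of the two measured values, and the gap to compound 1 at 17300 nM lies beyond the scatter. Compound 3 `Cc1ccccc1NC(=O)CN1CCN(c2nnc(Cc3ccncc3)c3ccccc23)CC1` differs from compound 2 in one place (2-methylphenyl in place of 3-chloro-4-fluorophenyl on an amide-type nitrogen): 2-methylphenyl in place of 3-chloro-4-fluorophenyl on an amide-type nitrogen. Within the data shown here, no measured pair shows this change alone. In this assay compound 1, which also carries 2-methylphenyl, gives 17300 nM and that value points upward. The expected rise (a 50-fold higher number from compound 2 to compound 3 (1.70 log units; beyond the scatter)) is estimated to lie beyond the scatter. For compound 3 the estimate is 200 nM (expected range 10 nM to 5000 nM).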

Compound 3, half-maximal inhibitory concentration: 200 nM
The estimate for compound 3 equals the measured number at the digits printed; measured number inside the range.
By their numbers in this assay, from the lowest: compound 2; then compound 3; then compound 1.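

In this assay compound 3 separates the two differences between compound 1 and compound 2 into single changes. On the amide-type nitrogen, 2-methylphenyl in place of 3-chloro-4-fluorophenyl gives a 50-fold higher number from compound 2 to compound 3 (1.70 log units; beyond the scatter), while pyridin-4-yl in place of phenyl on the saturated chain carbon gives an 87-fold lower number from compound 1 to compound 3 (1.94 log units; beyond the scatter), so each place matters on its own. Nothing at hand gives a reason for either step.

Open, from the compounds shown here alone, is how a plain phenyl or a 4-fluorophenyl on the amide-type nitrogen would read. Also open, going by these compounds, is what pyridin-3-yl or a carboxylic acid would do in place of pyridin-4-yl.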